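Same Swap, Second Core: Awaiting Compound 4's Number

A few compounds are considered here, and "the series" means these few. Any claim that something is new, unique, unknown or untested is made for them only; others in the source may bear on it.

Compound 1, `Cc1cc(NS(=O)(=O)c2ccc(/N=C/c3c(Cl)c4ccccc4oc3=O)cc2)no1`, and compound 2, `Cc1ccnc(NS(=O)(=O)c2ccc(/N=C/c3c(Cl)c4ccccc4oc3=O)cc2)n1`, share one core and differ only at the sulfonamide nitrogen. In a functional assay on B16-F10 cells (Mus musculus) for cytotoxicity, read by CCK-8 assay, with a stated time of 48 h (a lower number here means a stronger inhibitor, a higher number a weaker inhibitor), compound 1 gives 270 nM, and in this assay compound 2 gives 230 nM. The change between them is 4-methylpyrimidin-2-yl in place of 5-methyl-1,2-oxazol-3-yl on a sulfonamide nitrogen, and the step it made was a 1.2-fold lower number from compound 1 to compound 2 (0.07 log units; within the scatter), so the two compounds cannot be separated by this reading.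

Compound 3, `Cc1cc(NS(=O)(=O)c2ccc(/N=C/c3c(Cl)c4cc(C(C)(C)C)cc(C(C)(C)C)c4oc3=O)cc2)no1`, carries the same sulfonamide substituent as compound 1 on a different core; the difference between the two cores is not broken down here. In this assay compound 3 gives 240 nM, a number that sits alongside those of compound 1 and compound 2 without any of the three standing apart.

Compound 4, `Cc1ccnc(NS(=O)(=O)c2ccc(/N=C/c3c(Cl)c4cc(C(C)(C)C)cc(C(C)(C)C)c4oc3=O)cc2)n1`, has not yet been measured. It differs from compound 3 by 4-methylpyrimidin-2-yl in place of 5-methyl-1,2-oxazol-3-yl on a sulfonamide nitrogen, the same change at the same place that turned compound 1 into compound 2. Since the earlier step was a 1.2-fold lower number from compound 1 to compound 2 (0.07 log units; within the scatter), the step from compound 3 to compound 4 is expected to be of similar size, estimated as a 1.1-fold lower number from compound 3 to compound 4 (0.06 log units; within the scatter). On that basis compound 4 is expected to give about 210 nM in this assay, with a likely range from 110 nM to 400 nM. Whether the second core carries the swap as quietly as the first, the measurement will tell.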

Compound 4, half-maximal inhibitory concentration: 190 nM
For compound 4 the middle estimate is 1.1-fold (0.04 log units) above the measured one; the range from low to high includes it.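

On the second core, 4-methylpyrimidin-2-yl in place of 5-methyl-1,2-oxazol-3-yl on the sulfonamide nitrogen gives a 1.3-fold lower number from compound 3 to compound 4 (0.10 log units; within the scatter) in this assay, so this pair, like the first, cannot be separated by this reading. Set side by side, the two steps show no detectable difference between the cores, and the swap carries from one to the other without a visible change in its outcome: the same change on two cores in this assay, a 1.2-fold lower number (0.07 log units; within the scatter) from compound 1 to compound 2 and a 1.3-fold lower number (0.10 log units; within the scatter) from compound 3 to compound 4, 1.1-fold (0.03 log units) apart, within the scatter of two such steps

Within the data shown here, this shows only that the swap left no effect that can be told from the scatter on either core; it does not show that the swap has a real effect in either direction, and two pairs give no rule for a further core or for any other assay.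

The compounds shown leave open how the reading would respond to a quite different group on the sulfonamide nitrogen, such as a thiazol-2-yl ring, a plain methyl group or a bare hydrogen, since only two substituents appear there. They also leave open what would follow if the chlorine on the core gave way to a methoxy group or an amine, or if the imine link gave way to an amide.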